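The source may hold more compounds than are shown below. What is called first, only, known or untested is meant among the compounds shown, and "the series" means these compounds.

Measured compounds in the series:

- compound 1, `CCCSC[C@H](NC(C)=O)C(=O)CCl`, 6900 nM
- compound 2, `CCCCSC[C@H](NC(C)=O)C(=O)CCl`, 41400 nM
- compound 3, `CCCCCCSC[C@H](NC(C)=O)C(=O)CCl`, 3300 nM

In a functional assay on NALM-6 cells (Homo sapiens) (a higher number here means a weaker inhibitor, a lower number a stronger inhibitor), compound 3 gives 3300 nM, the lowest number of the three measured; compound 1 is nearest and compound 2 furthest from it.

Compound 4, `CCCCCCCCCCCCSC[C@H](NC(C)=O)C(=O)CCl`, is not yet measured in this assay. It differs from compound 3 by hexyl in place of hydrogen on a saturated chain carbon, six bonds along the chain from a sulfur.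

Among the compounds with values here, the steps that bear on chain lengthening at this position run in both directions. The step of a 6.0-fold higher number from compound 1 to compound 2 (0.78 log units; beyond the scatter) raised the number, whereas a 2.1-fold lower number from compound 1 to compound 3 (0.32 log units; beyond the scatter) and a 13-fold lower number from compound 2 to compound 3 (1.10 log units; beyond the scatter) lowered it. Only three points exist, and they do not form a single smooth trend, so the effect of a much longer chain is uncertain. Taking the direction of the two steps toward compound 3 as the best guide, a modest further lowering, or no change beyond the scatter, is expected: the step of a 1.7-fold lower number from compound 3 to compound 4 (0.22 log units; within the scatter) is the estimate. Compound 4 is therefore expected to give about 2000 nM in this assay, with a range from 500 nM to 12000 nM.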

Compound 4, half-maximal inhibitory concentration: 2000 nM
Estimate against measurement, compound 4: no gap at the digits printed; low and high end bracket the measured number.
By their numbers in this assay, from the lowest: compounds 4 and 3 (each within the scatter of the next); then compound 1; then compound 2.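

In this assay, the step of hexyl in place of hydrogen on a saturated chain carbon, six bonds along the chain from a sulfur, gives a 1.7-fold lower number from compound 3 to compound 4 (0.22 log units; within the scatter) and so leaves compound 3 and compound 4 indistinguishable. This position therefore accepts a much longer chain with no loss of activity, which the shorter chains could not show. Compound 2 still goes against any simple reading by chain length, given a 13-fold lower number from compound 2 to compound 3 (1.10 log units; beyond the scatter) and no data available here account for the flat result at the long end of the series.

Open, on these data alone, is whether a still longer chain, or an amine or a carboxylic acid at the chain end, would keep the number in this range. Also open, as far as these compounds go, is whether the high number of compound 2 would hold on repeat measurement.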